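A few compounds are considered here, and "the series" means these few. Any claim that something is new, unique, unknown or untested is made for them only; others in the source may bear on it.

Compound 3 `COc1ccc(OC)c(-n2nncc2CN2C(=O)C3(C(C#N)=C(N)Oc4c(N)cc5nc6ccccc6nc5c43)c3ccccc32)c1` carries a 2,5-dimethoxyphenyl group on an aromatic nitrogen of the shared core. In an ADME assay on L02 cells (Homo sapiens) for antiproliferative activity, read by MTT assay, with a stated time of 48 h (a lower number here means a stronger inhibitor, a higher number a weaker inhibitor), compound 3 gives > 50000 nM, and this is a limit of the assay rather than a measured number. Two companions share that core and differ only in the group on the same aromatic nitrogen: compound 1 `N#CC1=C(N)Oc2c(N)cc3nc4ccccc4nc3c2C12C(=O)N(Cc1cnnn1-c1ccc(F)cc1)c1ccccc12` carries a 4-fluorophenyl group, and compound 2 `Cc1cc(C)cc(-n2nncc2CN2C(=O)C3(C(C#N)=C(N)Oc4c(N)cc5nc6ccccc6nc5c43)c3ccccc32)c1` carries a 3,5-dimethylphenyl group. In this assay compound 1 gives > 50000 nM, again a limit. Compound 2 gives > 50000 nM in this assay, also a limit. Among the measured compounds shown here, because all three values sit at the limit of > 50000 nM in this assay, at which 3 of the 3 values shown sit, no step among them can be sized: the step that the two limits leave unreadable from compound 1 to compound 2, the step that the two limits leave unreadable from compound 1 to compound 3 and the step that the two limits leave unreadable from compound 2 to compound 3 are all unreadable.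

Compound 4 `COc1cc(-n2nncc2CN2C(=O)C3(C(C#N)=C(N)Oc4c(N)cc5nc6ccccc6nc5c43)c3ccccc32)c(OC)cc1Cl` differs from compound 3 by one change: chloro in place of hydrogen on an aromatic carbon. The three measured steps bear on it only by showing that every change to this phenyl group so far has left the value at the limit; they give no size and no direction. The expectation for compound 4 in this assay is therefore that it also reaches the limit rather than a number, with an estimated value of 60000 nM and a range from 20000 nM to 150000 nM. The expected step is a step that the limit leaves unreadable from compound 3 to compound 4, which carries no readable meaning against a limit.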

Compound 4, half-maximal inhibitory concentration: > 50000 nM
Compound 4: no number, only a limit; the forecaster's own chance of this, stated with the estimate: 85%; the middle value lies beyond the limit too.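

In this assay compound 4 gives > 50000 nM, which is a limit and not a measured number. No step between compound 4 and compound 1, compound 2 or compound 3 can be read, because every value sits at the same limit: the limit of > 50000 nM in this assay, at which 4 of the 4 values shown sit. The compounds shown leave open whether any of these phenyl groups changes the true value, and by how much.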